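The source may report more compounds than this note shows. Statements on the series, on what has been measured and on what is new or still open speak of the compounds shown alone.

Measured so far in a functional assay on the whole organism with Rattus norvegicus as the target, at a dose of 100 mg/kg; a lower number here means less inhibition, a higher number more inhibition at the dose given (going by the name of the read-out):
compound 1 `CC/N=C(\S)NCCCCCn1nc(-c2ccccc2)ccc1=O` gives 66.4%;
compound 2 `C/N=C(/NC#N)NCCCCCCn1nc(-c2ccccc2)ccc1=O` gives 31.7%.

Compound 1 stands highest of these two numbers; its nearest neighbour is compound 2, and the step of a number 34.7 percentage points lower from compound 1 to compound 2 (beyond the scatter) lies beyond the scatter. Compound 3 `N/C(S)=N/CCCCn1nc(-c2ccccc2)ccc1=O` has not yet been measured in this assay. It differs from compound 1 in the group at the end of the chain: a group of 4 heavy atoms (1 carbon, 2 nitrogen, 1 sulfur; no ring) in place of a group of 7 heavy atoms (4 carbon, 2 nitrogen, 1 sulfur; no ring), on a saturated chain carbon, four bonds along the chain from an aromatic nitrogen. For the measured compounds named here, the only measured step that bears on such a change is a number 34.7 percentage points lower from compound 1 to compound 2 (beyond the scatter), where the end group of the chain was also exchanged, and the read-out fell by a large amount. That single step shows the end group can move the inhibition strongly, but it concerns a different replacement, so the direction for compound 3 is uncertain. For compound 3 a moderate drop is expected, a number 16.4 percentage points lower from compound 1 to compound 3 (beyond the scatter), with a wide range. The estimated value for compound 3 in this assay is 50%, between 25% and 75%.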

Compound 3, a percentage reported as inhibition, in the whole organism at one dose (the size of the read-out at that dose, not a potency): 72%
Compound 3: middle estimate off by 22 percentage points, on the low side; the range from low to high includes it.
By their numbers in this assay, from the lowest: compound 2; then compounds 1 and 3 (each within the scatter of the next).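

In this assay, placing the group of 4 heavy atoms where the group of 7 heavy atoms stood gives a number 5.6 percentage points higher from compound 1 to compound 3 (within the scatter) and so does not separate the two compounds. For the compounds shown here, this position, four bonds along the chain from an aromatic nitrogen, can therefore carry the smaller group with no loss of inhibition beyond the scatter, whereas the earlier step (a number 34.7 percentage points lower from compound 1 to compound 2 (beyond the scatter)) showed only that a change at the end of the chain can cost a great deal. Nothing measured here explains why the inhibition holds.

The compounds shown leave open whether the sulfur in the end group matters, which a urea with oxygen in its place would test. They also leave open whether a plain amine or a carboxylic acid at the chain end would keep this level of inhibition.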